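From Phenyl to 2-Hydroxyphenyl in Compound 3

The source may hold more compounds than are shown below. What is called first, only, known or untested is meant among the compounds shown, and "the series" means these compounds.

In a functional assay on HepG2 cells (Homo sapiens) for cytotoxicity, read by MTT assay, with a stated time of 48 h (on this read-out lower numbers stand for stronger inhibition and higher numbers for weaker inhibition), compound 1 (`COc1cc(/C=C/C(=O)C2=C(/C=C/c3ccc(O)c(OC)c3)NC(=O)NC2c2ccc(O)cc2)ccc1O`) gives 25000000 nM, and compound 2 (`COc1cc(/C=C/C(=O)C2=C(/C=C/c3ccc(O)c(OC)c3)NC(=O)NC2c2ccccc2)ccc1O`) gives 50000000 nM. Among the measured compounds shown here, these are the only two measurements so far, and they lie within the scatter of each other, so compound 2 cannot be separated from compound 1 on these numbers. Compound 3 (`COc1cc(/C=C/C(=O)C2=C(/C=C/c3ccc(O)c(OC)c3)NC(=O)NC2c2ccccc2O)ccc1O`) is the next case. It departs from compound 2 by hydroxy in place of hydrogen on an aromatic carbon, which places hydroxy in place of hydrogen on an aromatic carbon, ortho to a large group, turning phenyl into 2-hydroxyphenyl. For the measured compounds named here, one measured step bears on this change: a 2.0-fold higher number from compound 1 to compound 2 (0.30 log units; within the scatter). That step also exchanges hydroxy and hydrogen on an aromatic carbon, but compound 1 carries its hydroxy at a different place on the ring, so the parallel is only partial. The data hold no measurement of a hydroxy at the new place. No shift beyond the scatter is therefore expected in this assay. The expected step is a 1.6-fold lower number from compound 2 to compound 3 (0.19 log units; within the scatter), a small estimated move that stays within the scatter. The estimate for compound 3 is 32000000 nM, with an expected range from 13000000 nM to 80000000 nM.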

Compound 3, half-maximal inhibitory concentration: 100000000 nM
For compound 3 the middle estimate is 3.1-fold (0.49 log units) below the measured one; measured number outside the range, above it.
By their numbers in this assay, from the lowest: compounds 1, 2 and 3 (each within the scatter of the next, the first and the last beyond it).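

In this assay the hydroxy placed ortho to a large group gives a 2.0-fold higher number from compound 2 to compound 3 (0.30 log units; within the scatter) and so cannot be told apart from hydrogen at that place, just as the earlier hydroxy of compound 1 could not be told apart from hydrogen on the same ring. Among the compounds shown here, what the earlier compounds did not show comes from comparing the two hydroxy compounds: 2-hydroxyphenyl in place of 4-hydroxyphenyl gives a 4.0-fold higher number from compound 1 to compound 3 (0.60 log units; beyond the scatter) and is the first step in this set to pass beyond the scatter, though only modestly, while compound 2, with plain phenyl, stays within the scatter of both. So the place of the hydroxy on this ring can register in this assay even though neither hydroxy compound separates from compound 2, and nothing available offers a reason for this difference.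

The compounds shown leave open how a methoxy group, a fluorine atom or an amine in place of the hydroxy of 2-hydroxyphenyl would read in this assay. They also leave open whether the gap between 2-hydroxyphenyl and 4-hydroxyphenyl would hold with other groups on the shared core.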